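The source may report more compounds than this note shows. Statements on the series, on what has been measured and on what is new or still open speak of the compounds shown alone.

Of the compounds shown here, three have been measured in a functional assay on KB cells (Homo sapiens) for cytotoxicity, tested at 10 uM; on this read-out higher numbers stand for more inhibition at the one concentration tested (going by the name of the read-out) and lower numbers for less inhibition. Compound 1 `O=Cc1c(-c2ccc(Cl)cc2)sc2ccccc12` gives 67%, compound 2 `N#Cc1c(-c2ccc(Cl)cc2)sc2ccccc12` gives 29%, and compound 3 `N#Cc1ccccc1-c1sc2ccccc2c1C=O` gives 51%. Among these three numbers compound 2 stands lowest: its nearest neighbour is compound 3, and compound 1 stands furthest away. For the measured compounds named here, the only measured step between compounds that differ in a single place is a number 38 percentage points lower from compound 1 to compound 2 (beyond the scatter), a change to the group on the shared core rather than to the ring that carries the chloro.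

Compound 4 `N#Cc1c(-c2ccccc2)sc2ccccc12` differs from compound 2 in one place: hydrogen in place of chloro on an aromatic carbon. The chloro leaves and a hydrogen enters on an aromatic carbon of a six-membered aromatic ring of carbon only. Going by the values given here, no measured step shows what this change does in this assay, since a number 38 percentage points lower from compound 1 to compound 2 (beyond the scatter) concerns a different group and does not bear on it. With nothing pointing either way, the step expected here, no change at the digits printed from compound 2 to compound 4 (within the scatter), is none beyond the scatter. Compound 4 is therefore estimated at 29%, within a range from 10% to 50%.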

Compound 4, a percentage reported as inhibition, at one concentration (the size of the read-out at that concentration, not a potency): 42%
For compound 4 the middle estimate is 13 percentage points below the measured one, and the stated range covers the measured number.
By their numbers in this assay, from the lowest: compound 2; then compounds 4 and 3 (each within the scatter of the next); then compound 1.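

Hydrogen in place of chloro on an aromatic carbon, para to a large group, gives in this assay the first reading of a change on this ring: a number 13 percentage points higher from compound 2 to compound 4 (beyond the scatter), a modest step. For the compounds shown here, the chloro is therefore not required for inhibition in this nitrile pair, and the compound without it gives the higher number, so this position does affect the read-out, though only one pair shows it. Nothing available explains why the number moves in this direction.

The compounds shown leave open how a fluoro, a methoxy or an amine at this position would read. They also leave open whether hydrogen in place of chloro would act the same way with formyl rather than nitrile on the shared core.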